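Urea series: cytotoxicity notes toward compound 3

The source may report more compounds than this note shows. Statements on the series, on what has been measured and on what is new or still open speak of the compounds shown alone.

Measured so far in an ADME assay on BJ cells (Homo sapiens) for cytotoxicity, with a stated time of 72 h; a lower number here means that less compound is needed, a higher number that more compound is needed for the effect:
compound 1 `Cc1cc(NC(=O)Nc2ccc(C(C)(C)C)cc2)c2ccccc2n1` gives 20000 nM
compound 2 `CSc1ccccc1NC(=O)Nc1cc(C)nc2ccccc12` gives > 25000 nM, which is a limit of the assay and not a number

Going by the values given here, compound 1 is the only compound of the pair with a numerical reading in this assay; the other entry is a limit, (the limit of > 25000 nM in this assay, at which 1 of the 2 values shown sits), so the series so far gives one number and one bound, and no step between measured compounds that differ in one place exists to calibrate the size of a change.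

Compound 3 `Cc1cc(NC(=O)Nc2ccc(SC(F)(F)F)cc2)c2ccccc2n1` differs from compound 1 by (trifluoromethyl)sulfanyl in place of tert-butyl on an aromatic carbon. Among the compounds with values here, with no measured step to lean on, the expectation rests on compound 1 alone: the change from compound 1 to compound 3 is expected to stay within the usual scatter, so no change at the digits printed from compound 1 to compound 3 (within the scatter) is estimated as essentially no movement in either direction. Compound 3 is therefore expected to give about 20000 nM in this assay, with a range of 8000 nM to 40000 nM, and a real chance that only a limit is reported.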

Compound 3, half-maximal effective concentration: > 25000 nM
Compound 3: no number, only a limit (the forecaster's own chance of this, stated with the estimate: 40%); at least 1.2-fold (0.09 log units) between middle value and limit.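

Series notes after compound 3

Going by these compounds alone, on an aromatic carbon para to a large group, (trifluoromethyl)sulfanyl in place of tert-butyl gives the first step that can be read in this assay: an at least 1.2-fold higher number from compound 1 to compound 3 (0.09 log units; that floor lies within the scatter). Compound 3 gives > 25000 nM, which is a limit of the assay and not a number, so the step has only a floor and its true size stays unknown, and this reading now adds to the values held at that limit: the limit of > 25000 nM in this assay, at which 2 of the 3 values shown sit. The tert-butyl group of compound 1 is thus not needed at this position for a reading at this high end of the range shown, and this change gives no lower number in this assay.

The compounds shown leave open how far the number of compound 3 lies from the limit, and so whether this step is larger than the scatter. They also leave open how a group of another kind at this position, such as an amine or a carboxylic acid, would read against compound 1 at 20000 nM.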